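This account rests on a few compounds, and the source may have more. Where it says the series, first, only, none or still open, it means among the compounds named here.

The measured compounds, in an assay on cells for inhibition of HSP60/HSP10 (Homo sapiens), with a stated time of 60 min; a higher number here means a weaker inhibitor, a lower number a stronger inhibitor:
compound 1 `O=S(=O)(Nc1ccc(-c2nc3ccccc3o2)cc1)c1ccc(F)c(C(F)(F)F)c1`, 28000 nM;
compound 2 `CCc1ccc(S(=O)(=O)Nc2ccc(-c3nc4ccccc4o3)cc2)cc1`, > 100000 nM, a limit of the assay rather than a number;
compound 3 `O=S(=O)(Nc1ccc2oc(-c3ccccc3)nc2c1)c1ccc(O)cc1`, 88000 nM.

Compound 2 stands at the top edge of what this assay reports: for compound 2 only the limit > 100000 nM is known, and (the limit of > 100000 nM in this assay, at which 1 of the 3 values shown sits). Compound 1 and compound 3 give numbers. Compound 4 `O=S(=O)(Nc1ccc(-c2nc3ccccc3o2)cc1)c1ccc(O)cc1` has not yet been measured in this assay. It differs from compound 2 by hydroxy in place of ethyl on an aromatic carbon. Among the compounds with values here, no step between two measured compounds is recorded, so the size of this change can only be guessed. Compound 3 also carries the 4-hydroxyphenyl, on a different core, and gives 88000 nM, a number rather than a limit. The step is therefore expected to be an at least 1.2-fold lower number from compound 2 to compound 4 (0.09 log units; that floor lies within the scatter), bringing the value into the measurable range. Compound 4 is estimated at 80000 nM, between 25000 nM and 250000 nM.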

Compound 4, half-maximal inhibitory concentration: 78000 nM
For compound 4 the middle estimate is 1.0-fold (0.01 log units) above the measured one, within the range that was stated.
By their numbers in this assay, from the lowest: compound 1; then compounds 4 and 3 (each within the scatter of the next). At a limit, above all of these: compound 2.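

The change from 4-ethylphenyl to 4-hydroxyphenyl gives, in this assay, an at least 1.2-fold lower number from compound 2 to compound 4 (0.10 log units; that floor lies within the scatter). On these data alone, compound 2 stands at a limit, so this step is only a floor and its true size stays unknown: the limit of > 100000 nM in this assay, at which 1 of the 4 values shown sits. Even so, compound 4 gives a number at this position where compound 2 gives only a limit.

The compounds shown leave open whether the hydroxy itself or merely the loss of ethyl accounts for this. They also leave open how an amine, a carboxylic acid or a methoxy group would read at the same place.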